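Azidomethyl exchange on the carbonyl of compound 1

This account rests on a few compounds, and the source may have more. Where it says the series, first, only, none or still open, it means among the compounds named here.

Values so far in a functional assay on HCT-116 cells (Homo sapiens) for inhibition, read by MTT assay, with a stated time of 48 h; on this read-out higher numbers stand for weaker inhibition and lower numbers for stronger inhibition
- compound 1 `C/C=C/C(=O)N(Cc1cc(OC)c(OC)c(OC)c1)c1ccc(OC)c(O)c1` gives 8450 nM
- compound 2 `COc1ccc(CN(C(=O)CO)c2cc(OC)c(OC)c(OC)c2)cc1O` gives 520 nM
- compound 3 `COc1ccc(CN(C(=O)CCCl)c2cc(OC)c(OC)c(OC)c2)cc1O` gives 150 nM

Compound 1 has the highest number of the three and so the weakest inhibition here, and its gaps to compound 2 and to compound 3 both lie beyond the scatter. The next compound to be read, compound 4 `COc1ccc(N(Cc2cc(OC)c(OC)c(OC)c2)C(=O)CN=[N+]=[N-])cc1O`, keeps the core of compound 1 and changes one group, azidomethyl in place of prop-1-en-1-yl on a carbonyl carbon.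

Among the measured compounds shown here, no measured step covers this exchange, and none links compound 1 to compound 2 or compound 3. The nearest evidence is one modest step, a 3.5-fold lower number from compound 2 to compound 3 (0.54 log units; beyond the scatter), with chloromethyl in place of hydroxy on a saturated chain carbon bound to a carbonyl carbon. That step involves different groups, so it supports only a rough expectation of size. A modest move towards a lower number is expected in this assay, and no change beyond the scatter remains possible. The expected step is a 2.8-fold lower number from compound 1 to compound 4 (0.45 log units; beyond the scatter), an uncertain estimate. For compound 4 the estimated value is 3000 nM, with an expected range from 500 nM to 15000 nM.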

Compound 4, half-maximal inhibitory concentration: 38800 nM
Compound 4: middle estimate off by 13-fold (1.11 log units), on the low side; measured number above the stated range.
By their numbers in this assay, from the lowest: compound 3; then compound 2; then compound 1; then compound 4.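

In this assay, among the compounds shown here, the exchange of prop-1-en-1-yl for azidomethyl on the carbonyl carbon gives a 4.6-fold higher number from compound 1 to compound 4 (0.66 log units; beyond the scatter), the first measured step at this carbonyl on the core of compound 1, and it shows that this place responds to a change of group and that azidomethyl does not improve on prop-1-en-1-yl here. For the compounds shown here, the only earlier step, a 3.5-fold lower number from compound 2 to compound 3 (0.54 log units; beyond the scatter), ran towards a lower number, but with other groups and on a different core, so the two steps differ in direction without forming a trend at the carbonyl. No measurement at hand accounts for the higher number of compound 4, and the step records a direction and a size without a cause.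

The compounds shown do not separate the effect of removing prop-1-en-1-yl from that of introducing azidomethyl, and on the core of compound 1 an aminomethyl group or a saturated butyl chain on the carbonyl carbon would bear on that question. Going by these compounds alone, no step connects compound 1 or compound 4 with compound 2 or compound 3, so it remains open whether the hydroxymethyl and chloroethyl groups of those two compounds would rank the same way on the core of compound 1.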